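The compounds below may be only part of what the source reports. "The series", "measured", "known", "first", "only" and "open" are said of these compounds alone.

Working notes on the series. Among the compounds with values here, compound 1 `Cc1cc(C)cc(SCc2ccc(/C=C/C(=O)Nc3ccccc3N)cc2)c1` is one of two compounds measured in a functional assay on HeLa cells (Homo sapiens) for inhibition, read by CCK-8 assay, with a stated time of 72 h, tested at 8 uM; a higher number here means more inhibition of growth at the concentration tested, a lower number less inhibition of growth; in this assay compound 1 gives 3.39%. Compound 2 `Nc1ccccc1NC(=O)c1ccc(CSCCc2ccccc2)cc1` gives 74.8% in this assay. Within the data shown here, of the two numbers, compound 1 stands lowest, and the gap to compound 2 lies beyond the scatter; no single-change step links the two, so only the two values themselves can be read.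

Compound 3 `CCc1ccc(SCc2ccc(/C=C/C(=O)Nc3ccccc3N)cc2)cc1` has not yet been measured in this assay. It differs from compound 1 by 4-ethylphenyl in place of 3,5-dimethylphenyl on a sulfur: the two carry the same atoms joined differently, the change sitting on a sulfur whose other neighbour is a saturated chain carbon. No measured pair shows a step of this kind, so nothing shown speaks for a large change. The expected step is a number 4.6 percentage points higher from compound 1 to compound 3 (within the scatter), within the scatter. For compound 3 the estimate in this assay is 8%, with a range from 0% to 25%.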

Compound 3, percent growth inhibition at one concentration: 20.9%
Compound 3: middle estimate off by 12.9 percentage points, on the low side; the range from low to high includes it.
By their numbers in this assay, from the lowest: compound 1; then compound 3; then compound 2.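

In this assay, 4-ethylphenyl in place of 3,5-dimethylphenyl on a sulfur gives a number 17.5 percentage points higher from compound 1 to compound 3 (beyond the scatter), a modest step. Within the data shown here, this is the first reading at this place, and it shows that the number responds to the group on the sulfur even when the atoms stay the same and are only joined differently. No measurement shown accounts for the step.

The change removes the two methyl groups and introduces the ethyl group in a single move, so the contribution of each remains unresolved. Also open, on these data alone, is how an unsubstituted phenyl, a 4-methylphenyl or a longer chain such as 4-propylphenyl on the same sulfur would read in this assay, and whether an amine or a carboxylic acid on that ring would be tolerated.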